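The source may hold more compounds than are shown below. What is called first, only, known or untested is meant among the compounds shown, and "the series" means these compounds.

Measured compounds:
- compound 1, `COc1ccc(C2CC(c3ccc(NC(=O)c4cc(Cl)ccc4OC)cc3)=NN2C)cc1`: 88.1%
- compound 2, `COc1ccc(Cl)cc1C(=O)Nc1ccc(C2=NN(C)C(c3ccccc3[N+](=O)[O-])C2)cc1`: 96.5%
- compound 3, `COc1ccc(C2CC(c3ccc(NC(=O)c4cc(Cl)ccc4OC)cc3)=NN2c2ccccc2)cc1`: 94.8%

In a functional assay on the whole organism (strain albino) with Rattus norvegicus as the target, read by paw edema, with stated times of 1 h and 4 h, at a dose of 25 mg/kg by the oral route (on this read-out higher numbers stand for a stronger effect at the one dose given and lower numbers for a weaker effect), compound 3 gives 94.8%. Its number lies within the usual scatter of both other measured compounds: compound 2 is the nearest, and compound 1 the furthest, yet neither gap reaches beyond what repeated measurements of this kind show. The change from compound 1 to compound 3, phenyl in place of methyl on an amine nitrogen in a ring, gave a number 6.7 percentage points higher from compound 1 to compound 3 (within the scatter).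

Compound 4, `COc1ccc(Cl)cc1C(=O)Nc1ccc(C2=NN(c3ccccc3)C(c3ccccc3[N+](=O)[O-])C2)cc1`, differs from compound 3 in one place: 2-nitrophenyl in place of 4-methoxyphenyl on a saturated ring carbon. The same exchange has already been made once among the measured compounds, on the shared core carrying methyl on the ring nitrogen, where it gave a number 8.4 percentage points higher from compound 1 to compound 2 (within the scatter). That single step is the only one that bears on the present case, and it stayed within the scatter. Compound 4 is therefore expected to show no step beyond the scatter against compound 3, an estimated a number 1.7 percentage points higher from compound 3 to compound 4 (within the scatter), with the numbers already close to the top of the read-out. For compound 4 the estimate in this assay is 96.5%, expected to fall between 89% and 100%.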

Compound 4, a percentage reported as activity, at one dose (the size of the read-out at that dose, not a potency): 80.2%
Estimate against measurement, compound 4: 16.3 percentage points above; the measured number lies below the stated range.
By their numbers in this assay, from the lowest: compounds 4, 1, 3 and 2 (each within the scatter of the next, the first and the last beyond it).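

The exchange of 4-methoxyphenyl for 2-nitrophenyl on the saturated ring carbon carries no fixed effect from one core to the other in this assay: with phenyl on the ring nitrogen it gave a number 14.6 percentage points lower from compound 3 to compound 4 (beyond the scatter), whereas the same exchange had stayed within the scatter with methyl there, as the comparison shows: the same change on two cores in this assay, a number 8.4 percentage points higher (within the scatter) from compound 1 to compound 2 and a number 14.6 percentage points lower (beyond the scatter) from compound 3 to compound 4, 23 percentage points apart, beyond the scatter of two such steps. Read from the other side, phenyl in place of methyl on the amine nitrogen in the ring gave a number 16.3 percentage points lower from compound 2 to compound 4 (beyond the scatter) when 2-nitrophenyl sits on the saturated ring carbon, so the outcome of that change also depends on the group at the other place: the same change on two cores in this assay, a number 6.7 percentage points higher (within the scatter) from compound 1 to compound 3 and a number 16.3 percentage points lower (beyond the scatter) from compound 2 to compound 4, 23 percentage points apart, beyond the scatter of two such steps. The two places therefore do not add up among these compounds, since each change made on compound 1 stayed within the scatter, yet each lowered the number beyond it once the other was in place.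

The compounds shown leave open whether this dependence extends to other groups, such as 4-nitrophenyl on the saturated ring carbon or benzyl on the ring nitrogen. They also cannot tell what lies behind it, or how the compounds would rank at doses other than the one given.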